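Swapping ethynyl for bromo on the shared core

The source may report more compounds than this note shows. Statements on the series, on what has been measured and on what is new or still open speak of the compounds shown alone.

compound 1 `C=Cc1nc2ccccc2[se]1` gives the limit > 40000 nM
compound 2 `C=Cc1nc2ccccc2s1` gives the limit > 40000 nM
compound 3 `C#Cc1nc2ccccc2[se]1` gives 25000 nM
compound 4 `Brc1nc2ccccc2[se]1` is not yet measured

Going by the values given here, in a functional assay on HCT-116 cells (Homo sapiens) for cytotoxicity, with a stated time of 3 days (on this read-out lower numbers stand for stronger inhibition and higher numbers for weaker inhibition), compound 3 gives 25000 nM as the only true number so far. Compound 1 shows only a limit (> 40000 nM). Compound 2 also shows only a limit (> 40000 nM). The comparison therefore rests on the limit of > 40000 nM in this assay, at which 2 of the 3 values shown sit, and on a single number.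

Going from compound 3 to compound 4 puts bromo in place of ethynyl on an aromatic carbon. Among the compounds with values here, one measured step bears on this same carbon, ethynyl in place of vinyl. It is an at least 1.6-fold lower number from compound 1 to compound 3 (0.20 log units; that floor lies within the scatter) and so shows no clear change. Within the data shown here, no measured compound yet carries bromo, so this evidence is only indirect. No step beyond the scatter is therefore expected in this assay, in either direction, although compound 4 could well return only a limit. The estimated change is a 1.2-fold higher number from compound 3 to compound 4 (0.08 log units; within the scatter) and stays within the scatter. The estimate for compound 4 is 30000 nM, with an expected range (12000 nM to 50000 nM).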

Compound 4, half-maximal inhibitory concentration: > 40000 nM
Compound 4: a limit, no number; the forecaster's own chance of this, stated with the estimate: 45%; at least 1.3-fold (0.12 log units) between middle value and limit.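

At this aromatic carbon, next to the ring nitrogen and the ring selenium, putting bromo in place of ethynyl in this assay gives an at least 1.6-fold higher number from compound 3 to compound 4 (0.20 log units; that floor lies within the scatter), so this change shows no step beyond the scatter, although the real step could be larger, since only its floor is known. Ethynyl in compound 3 therefore remains the only group at this carbon with a true number, while vinyl in compound 1 and bromo in compound 4 both end as limits. The step between compound 1 and compound 4 cannot be read because both values are limits, and most of the series now rests on one limit: the limit of > 40000 nM in this assay, at which 3 of the 4 values shown sit.

From the compounds shown here alone, whether an amine, a carboxylic acid or a longer chain on this carbon would give a true number, and whether that number would lie clearly beneath that of compound 3, stays open. Going by these compounds alone, the part played by the ring selenium is open too: compound 1 and compound 2, the only pair here that differs in that atom, both end as limits, and no compound pairs ethynyl with the core of compound 2.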